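Changing the ring on the carbon double-bonded to nitrogen

The source may hold more compounds than are shown below. What is called first, only, known or untested is meant among the compounds shown, and "the series" means these compounds.

Of the compounds shown here, two have been measured in a functional assay on MDA-MB-231 cells (Homo sapiens) for cytotoxicity, read by MTT assay, with a stated time of 48 h; on this read-out higher numbers stand for weaker inhibition and lower numbers for stronger inhibition. Compound 1 `COc1ccc(OC)c(C2=NOC(COc3ccc(-c4nnnn4-c4cc(OC)c(OC)c(OC)c4)cc3N)C2)c1` gives 3500 nM, and compound 2 `COc1cc(C2=NOC(COc3ccc(-c4nnnn4-c4cc(OC)c(OC)c(OC)c4)cc3N)C2)cc(OC)c1OC` gives 3230 nM. Going by the values given here, the only step seen so far, a 1.1-fold lower number from compound 1 to compound 2 (0.03 log units; within the scatter), swaps one methoxy-bearing ring for another on the shared core while leaving everything else in place. Compound 2 stands at the lowest of the two numbers, but its gap to compound 1 is within the scatter, so the two cannot be told apart.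

Compound 3 `COc1ccc(C2=NOC(COc3ccc(-c4nnnn4-c4cc(OC)c(OC)c(OC)c4)cc3N)C2)cc1[N+](=O)[O-]` has not yet been measured in this assay. It differs from compound 2 in one place: 4-methoxy-3-nitrophenyl in place of 3,4,5-trimethoxyphenyl on a carbon with a double bond to nitrogen. Among the compounds with values here, the one measured step, from compound 1 to compound 2, bears on it in that it also replaced the ring at this position, and it left the number essentially unchanged. Within the data shown here, no step yet shows a nitro group at this site, so the expectation rests on that single comparison. Compound 3 is therefore expected to land close to compound 2, with an estimated step of a 1.1-fold higher number from compound 2 to compound 3 (0.05 log units; within the scatter). The estimate for compound 3 is 3600 nM, with a range from 1500 nM to 9000 nM.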

Compound 3, half-maximal inhibitory concentration: 3560 nM
Estimate against measurement, compound 3: 1.0-fold (0.00 log units) above, within the range that was stated.
By their numbers in this assay, from the lowest: compounds 2, 1 and 3 (each within the scatter of the next).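

In this assay, putting 4-methoxy-3-nitrophenyl in place of 3,4,5-trimethoxyphenyl gives a 1.1-fold higher number from compound 2 to compound 3 (0.04 log units; within the scatter), and putting the same ring in place of 2,5-dimethoxyphenyl gives a 1.0-fold higher number from compound 1 to compound 3 (0.01 log units; within the scatter). The earlier pair compared only rings with different sets of methoxy groups, whereas this ring keeps a single methoxy group and adds a nitro group, and the three compounds still cannot be told apart in this assay, so at this position, next to the ring nitrogen, the tolerated rings now extend beyond methoxy-only patterns. Nothing available here offers an explanation for this result.

On these data alone, all three rings at this position are phenyl rings that carry at least one methoxy group, so it remains open how an unsubstituted phenyl ring, or a phenyl ring carrying an amine or a carboxylic acid instead, would compare. As far as these compounds go, it is also open whether a much larger change here, such as replacing the phenyl ring with a simple alkyl chain, would move the number beyond the usual scatter of this measurement.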